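Trifluoromethyl in Place of Chloro on Compound 2

The compounds below may be only part of what the source reports. "The series", "measured", "known", "first", "only" and "open" are said of these compounds alone.

Of the compounds shown here, two have numbers so far in an ADME assay on the whole organism (strain Balb) for pharmacokinetics, with Mus musculus as the target, at a dose of 10 mg/kg by the oral route (on this read-out lower numbers stand for lower oral bioavailability and higher numbers for higher oral bioavailability), so far. Compound 1 `NC(=O)c1cc(-c2ccnc(N)n2)[nH]c1-c1cc(C(F)(F)F)ccc1Cl` gives 31% and compound 2 `CCc1ccc(Cl)cc1-c1[nH]c(-c2ccnc(N)n2)cc1C(N)=O` gives 17% in that test. Compound 2 is therefore the lower of the two, and the gap lies beyond the usual scatter of repeated measurements. The next compound, compound 3 `CCc1ccc(C(F)(F)F)cc1-c1[nH]c(-c2ccnc(N)n2)cc1C(N)=O`, has trifluoromethyl in place of chloro on an aromatic carbon, para to an ethyl group (trifluoromethyl in place of chloro on an aromatic carbon). Going by the values given here, no measured pair shows this swap on its own, so its size cannot be read directly. Among the compounds with values here, the only other trifluoromethyl compound here is compound 1 at 31% and it lacks the ethyl group, so only a small upward step, or none beyond the scatter, is expected in this assay for this change. The estimated change is a number 5 percentage points higher from compound 2 to compound 3 (within the scatter) and stays within that scatter. For compound 3 the estimate is 22% with 10% to 38% as the expected range.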

Compound 3, oral bioavailability: 24%
Compound 3: middle estimate off by 2 percentage points, on the low side; low and high end bracket the measured number.
By their numbers in this assay, from the lowest: compounds 2, 3 and 1 (each within the scatter of the next, the first and the last beyond it).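

In this assay, trifluoromethyl in place of chloro, para to an ethyl group, gives a number 7 percentage points higher from compound 2 to compound 3 (within the scatter) and so no change that can be told apart from repeat measurements. With trifluoromethyl kept, ethyl in place of chloro on an aromatic carbon gives a number 7 percentage points lower from compound 1 to compound 3 (within the scatter) and is likewise no clear change, so neither single swap has a measurable effect on its own. Nothing available here offers a reason for either step.

From the compounds shown here alone, whether an amine, a methoxy group or a carboxylic acid in this same position would shift oral bioavailability beyond the scatter remains open. So does whether a longer chain in place of the ethyl group would do so.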